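Lengthening the hydroxamic acid chain on compound 1

The source may report more compounds than this note shows. Statements on the series, on what has been measured and on what is new or still open speak of the compounds shown alone.

Compound 1 (`Nc1ncnc2c1c(-c1cnc3[nH]ccc3c1)nn2CC(=O)NO`) stands at the top of the range in a functional assay on HepG2 cells (Homo sapiens) for inhibition, read by MTT assay, with a stated time of 72 h; a lower number here means a stronger inhibitor, a higher number a weaker inhibitor. In this assay compound 1 gives > 150000 nM, which is a limit and not a number. Compound 4 (`Nc1ncnc2c1c(-c1cnc3[nH]ccc3c1)nn2CCCCCCC(=O)NO`) carries 5-(hydroxycarbamoyl)pentyl in place of hydroxycarbamoyl on a saturated chain carbon bound to an aromatic nitrogen.

Going by the values given here, only two other compounds bear on this change, and both have a core different from that of compound 1. Compound 2 (`Nc1nc2cc(-c3nn(CCCCCCCCCC(=O)NO)c4ncnc(N)c34)ccc2o1`), with the longest chain here, gives 28600 nM. Compound 3 (`Nc1nc2cc(-c3nn(CCC(=O)NO)c4ncnc(N)c34)ccc2o1`) gives > 150000 nM, again a limit. Among the compounds with values here, the one measured step is an at least 5.2-fold higher number from compound 2 to compound 3 (0.71 log units; beyond the scatter), with hydroxycarbamoyl replacing 7-(hydroxycarbamoyl)heptyl on a saturated chain carbon, two bonds along the chain from an aromatic nitrogen. Within the data shown here, this single pair links the longer chain to the lower number, and no compound here goes against it, though one pair on another core is thin support.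

Because compound 2 reaches 28600 nM, a measurable number is expected for compound 4, although compound 4 may still show none. The expected change is an at least 5.0-fold lower number from compound 1 to compound 4 (0.69 log units; beyond the scatter), in the direction of stronger inhibition. For compound 4 the estimated value is 30000 nM, with an expected range of 6000 nM to 150000 nM.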

Compound 4, half-maximal inhibitory concentration: 10300 nM
Compound 4: middle estimate off by 2.9-fold (0.46 log units), on the high side, within the range that was stated.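

On the core of compound 1 itself, 5-(hydroxycarbamoyl)pentyl in place of hydroxycarbamoyl on a saturated chain carbon bound to an aromatic nitrogen gives an at least 14-fold lower number from compound 1 to compound 4 (1.16 log units; beyond the scatter) in this assay. The link between the longer chain and the lower number therefore no longer rests on the pair on the other core alone: compound 2 and compound 3 run the same way, and none of the four compounds goes against it. As far as these compounds go, the true size of the new step stays unknown, and the printed figure is only a minimum, because compound 1 gives no number at its end of the comparison: the limit of > 150000 nM in this assay, at which 2 of the 4 values shown sit.

Still open, from the compounds shown here alone, is how the number runs on the core of compound 1 with a longer chain such as 7-(hydroxycarbamoyl)heptyl, or with lengths in the stretch from hydroxycarbamoyl to 5-(hydroxycarbamoyl)pentyl, so neither a steady trend nor a best length can be claimed. Also open, going by these compounds, is how much of the reading depends on the hydroxamic acid end of the chain, a question that a carboxylic acid or a primary amide at the same chain end would address.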